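A few compounds are considered here, and "the series" means these few. Any claim that something is new, unique, unknown or untested is made for them only; others in the source may bear on it.

Measured in a physicochemical assay for acid dissociation:
compound 1 `COc1cc(C(=O)N[C@@H]2CCC[C@@H]3CCN(C)C[C@H]32)cc(OC)c1OC`: 8.75
compound 2 `CN1CC[C@H]2CCC[C@@H](NC(=O)c3ccccc3)[C@H]2C1`: 9.18
compound 3 `COc1cc(C(=O)O[C@@H]2CCC[C@@H]3CCN(C)C[C@H]32)cc(OC)c1OC`: 8.82

In this assay, compound 3 at 8.82 lies within the scatter of compound 1 at 8.75. Compound 2 at 9.18 stands higher than both, beyond the scatter.

The change from compound 3 to compound 4 `COc1cc(C(=O)O[C@@H]2CCC[C@@H]3CCN(C)C[C@@H]32)cc(OC)c1OC` is the two compounds have the same atoms and bonds and differ only in configuration as drawn: 1 of 3 stereo elements differ; a stereocentre at a saturated ring carbon is drawn S in compound 3 and R in compound 4 and nothing else: the two compounds have the same atoms and bonds, and a stereocentre at a saturated ring carbon is drawn S in compound 3 and R in compound 4.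

Within the data shown here, no measured pair isolates a change of configuration, so the data offer no direct precedent for this step. No shift beyond the scatter is expected, with at most a slight upward drift. The estimated step is a number 0.08 log units higher from compound 3 to compound 4 (within the scatter) and is expected to stay within the scatter. For compound 4 the estimated value in this assay is 8.9, with an expected range of 8.5 to 9.3.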

Compound 4, acid dissociation constant: 8.91
Beside the measured number, compound 4's estimate is 0.01 log units below it, and the stated range covers the measured number.
By their numbers in this assay, from the lowest: compounds 1, 3, 4 and 2 (each within the scatter of the next, the first and the last beyond it).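

In this assay, among these compounds, changing a stereocentre at a saturated ring carbon from S to R gives a number 0.09 log units higher from compound 3 to compound 4 (within the scatter), the only measured step that isolates configuration. At this position, the S and R forms of the ester are therefore not separated by this read-out. The comparison is clean, with no second change to account for in the step: the fact that compounds 3 and 4 differ only in the configuration as drawn.

On these data alone, it remains open whether the same change of configuration would read alike in the amide series of compound 1, and whether the other two stereo elements of the shared core would behave as this one does. Also open, as far as these compounds go, is how this assay would read with a sulfonamide in place of the ester link, or with a longer chain in place of the methyl group on the core.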